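The compounds below may be only part of what the source reports. "The series", "measured", "known", "first", "only" and "open" are said of these compounds alone.

Working notes on the arylpiperazine series in a functional assay for antagonist activity at Alpha-1A adrenergic receptor (Oryctolagus cuniculus); a higher number here means weaker binding, a lower number tighter binding.

Of the compounds shown here, two have numbers so far. Compound 1, `COc1ccccc1N1CCN(CCCNc2ncccc2C(=O)NC(C)(C)C)CC1`, gives 1.26 nM in this assay. Compound 2, `CN(C)C(=O)c1cccnc1NCCCN1CCN(c2ccccc2OCC(F)(F)F)CC1`, gives 0.1 nM in this assay, the lowest of the two numbers; its nearest neighbour is compound 1, whose number is higher by a margin beyond the scatter. The two compounds differ in more than one place, so no single change can be read off from that gap.

Compound 3, `CCCc1ccccc1N1CCN(CCCNc2ncccc2C(=O)N(C)C)CC1`, has not been measured. It differs from compound 2 in one place: propyl in place of 2,2,2-trifluoroethoxy on an aromatic carbon. Among the measured compounds shown here, no measured pair shows this kind of exchange, so its size has to be guessed without a direct precedent. The step from compound 2 to compound 3 is expected to go toward a higher number, a 10-fold higher number from compound 2 to compound 3 (1.00 log units; beyond the scatter), beyond the scatter, though with a wide margin of doubt because compound 2 sits at 0.1 nM and nothing else in the set anchors the low end. Compound 3 is accordingly estimated at 1 nM in this assay, within a range from 0.2 nM to 5 nM.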

Compound 3, dissociation constant: 0.2 nM
Compound 3: middle estimate off by 5.0-fold (0.70 log units), on the high side; the measured number falls inside the stated range.
By their numbers in this assay, from the lowest: compounds 2 and 3 (each within the scatter of the next); then compound 1.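

In this assay, among the compounds shown here, propyl in place of 2,2,2-trifluoroethoxy gives a 2.0-fold higher number from compound 2 to compound 3 (0.30 log units; within the scatter), the first step that can be read at a single place. At this aromatic carbon, ortho to a large group, the two groups cannot be told apart, even though propyl brings only carbon and 3 heavy atoms, while 2,2,2-trifluoroethoxy brings oxygen, fluorine and 6 heavy atoms; for this pair, then, neither the oxygen nor the fluorine is required for a number in this range. Nothing available explains why the two groups read alike.

Still open, on these data alone, is whether this position would accept a group of a different kind, such as a primary amine or a carboxylic acid, or a longer chain such as hexyl, with the same result, since one pair sets no limit on what fits there. Also open, as far as these compounds go, is how much of the gap between compound 1 and compound 2 belongs to the amide and how much to the aromatic substituent, as those two compounds differ in more than one place.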